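Pyrimidin-2-yl in place of methyl on compound 2

The compounds below may be only part of what the source reports. "The series", "measured", "known", "first", "only" and "open" are said of these compounds alone.

compound 1 `CN(C[C@H]1Cc2c(cccc2N2CCN(C3CC3)CC2)CN1)[C@H]1CCCc2cccnc21` gives 7%
compound 2 `CN1CCN(c2cccc3c2C[C@H](CN(C)[C@H]2CCCc4cccnc42)NC3)CC1` gives 17%

Among the measured compounds shown here, in an ADME assay on microsomes from liver (Mus musculus) for metabolic stability, read by LC-MS, with a stated time of 10 min (a higher number here means that more of the compound is left, a lower number that less of the compound is left), compound 2 gives 17% and has only one measured neighbour, which lies within the scatter of it. Compound 3 `CN(C[C@H]1Cc2c(cccc2N2CCN(c3ncccn3)CC2)CN1)[C@H]1CCCc2cccnc21` keeps the shared core and differs from compound 2 at one place: pyrimidin-2-yl in place of methyl on an amine nitrogen in a ring. For the measured compounds named here, one measured step bears on this change, as it also replaces a group on an amine nitrogen in a ring: a number 10 percentage points higher from compound 1 to compound 2 (within the scatter). Going by the values given here, no measured compound carries pyrimidin-2-yl, so the evidence is indirect. With that single step as the guide, no step beyond the scatter is expected in this assay. The estimate is a number 5 percentage points lower from compound 2 to compound 3 (within the scatter). For compound 3 the expected value is 12%, with an estimated range from 3% to 30%.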

Compound 3, percent of the compound remaining: 35.1%
Compound 3: the middle estimate sits 23.1 percentage points below what was measured, and the stated range ends below it.
By their numbers in this assay, from the lowest: compounds 1 and 2 (each within the scatter of the next); then compound 3.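

Among the compounds shown here, on the amine nitrogen of the six-membered non-aromatic ring with 2 nitrogen, the exchange of cyclopropyl for methyl had stayed within the scatter, so the earlier compounds did not show that this position could matter in this assay. Pyrimidin-2-yl gives the first steps beyond the scatter, both modest (a number 18.1 percentage points higher from compound 2 to compound 3 (beyond the scatter); a number 28.1 percentage points higher from compound 1 to compound 3 (beyond the scatter)), which shows that the read-out responds to what this nitrogen carries. No measurement shown explains this rise.

From the compounds shown here alone, it remains open whether the rise needs the two ring nitrogens of pyrimidin-2-yl or would also come with a phenyl ring or a pyridin-2-yl group. Going by these compounds, it is equally open how an acetyl group on this nitrogen would compare with methyl, cyclopropyl and pyrimidin-2-yl.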